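This account rests on a few compounds, and the source may have more. Where it says the series, first, only, none or still open, it means among the compounds named here.

Compound 1, `O=c1ccoc2cc(OCc3cn(Cc4ccccc4)nn3)ccc12`. In a functional assay on MDA-MB-231 cells (Homo sapiens) for cytotoxicity, read by MTT assay, with a stated time of 48 h (a higher number here means a weaker inhibitor, a lower number a stronger inhibitor), compound 1 gives > 100000 nM, which is a limit of the assay and not a number.
Compound 2, `Cc1ccccc1Cn1cc(COc2ccc3c(=O)ccoc3c2)nn1`. In this assay compound 2 gives > 100000 nM, again a limit.
Compound 3, `O=c1ccoc2cc(OCc3cn(Cc4cccc(F)c4)nn3)ccc12`. In this assay compound 3 gives > 100000 nM, also a limit.

Compound 3 therefore stands at the limit, and so do the two other measured compounds, as all three values sit at the limit of > 100000 nM in this assay, at which 3 of the 3 values shown sit. The steps that reach compound 3 are correspondingly unreadable: a step that the two limits leave unreadable from compound 1 to compound 3, and likewise a step that the two limits leave unreadable from compound 2 to compound 3. The remaining step, a step that the two limits leave unreadable from compound 1 to compound 2, is unreadable for the same reason.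

Compound 4, `O=c1ccoc2cc(OCc3cn(Cc4cccc([N+](=O)[O-])c4)nn3)ccc12`, is the next member. Its difference from compound 3 is nitro in place of fluoro on an aromatic carbon. Going by the values given here, no measured step bears on this change in a readable way, since every value so far is a limit. On that footing nothing suggests a step beyond the scatter, and compound 4 is expected to remain at or near the limit, with the step from compound 3 estimated as a step that the limit leaves unreadable from compound 3 to compound 4. Compound 4 is accordingly estimated at 150000 nM in this assay, within a range of 40000 nM to 600000 nM.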

Compound 4, half-maximal inhibitory concentration: > 100000 nM
Compound 4: a limit, no number; the forecaster's own chance of this, stated with the estimate: 85%; the middle value is on the limit's open side.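

Compound 4 joins compound 1, compound 2 and compound 3 at the limit, so no step involving compound 4 can be read, in size or in direction: the limit of > 100000 nM in this assay, at which 4 of the 4 values shown sit.

The compounds shown leave open how these four compounds truly differ in this assay, and whether any change to the substituted phenyl group would give a value that is not a limit.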